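The source may report more compounds than this note shows. Statements on the series, on what has been measured and on what is new or still open speak of the compounds shown alone.

Three related compounds have been tested in a functional assay on OVCAR-3 cells (Homo sapiens) for inhibition, read by spectrophotometry and sulforhodamine B assay, with a stated time of 48 h; a lower number here means a stronger inhibitor of growth, a higher number a weaker inhibitor of growth. Compound 2 (`O=C1CS/C(=N/N=C/c2c[nH]c3ccccc23)N1c1cccc2ccccc12`) gives 25700 nM, the middle of the three numbers. Compound 1 (`Cc1ccc(N2C(=O)CS/C2=N/N=C/c2c[nH]c3ccc(Br)cc23)cc1`) has a higher number, 98500 nM, and compound 3 (`S=C(N/N=C/c1c[nH]c2ccc(Br)cc12)Nc1cccc2ccccc12`) a lower one, 1600 nM. Both gaps from compound 2 lie beyond the usual scatter.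

Compound 4 (`O=C1CS/C(=N/N=C/c2c[nH]c3ccc(Br)cc23)N1c1cccc2ccccc12`) has not yet been measured. It is compound 2 with a single change, bromo in place of hydrogen on an aromatic carbon. Among the measured compounds shown here, no measured pair differs by this change alone, so its effect has not been seen directly. Compound 1 at 98500 nM and compound 3 at 1600 nM both carry the bromo group, yet they fall on opposite sides of compound 2, so they give no clear direction. In this assay, only a small shift toward a lower number is expected, probably not beyond the scatter. The estimated change is a 1.3-fold lower number from compound 2 to compound 4 (0.11 log units; within the scatter). Compound 4 is estimated at 20000 nM, with an expected range of 6000 nM to 70000 nM.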

Compound 4, concentration for 50% growth inhibition: 5120 nM
For compound 4 the middle estimate is 3.9-fold (0.59 log units) above the measured one, and the stated range ends above it.
By their numbers in this assay, from the lowest: compound 3; then compound 4; then compound 2; then compound 1.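

In this assay, among the compounds shown here, a 5.0-fold lower number from compound 2 to compound 4 (0.70 log units; beyond the scatter) gives the first direct reading of bromo in place of hydrogen on an aromatic carbon. It shows that this single change, on the six-membered aromatic ring of carbon only that is part of the fused system, is enough to move the number beyond the usual scatter, toward stronger inhibition of growth. The position is therefore not a silent one in this series, though nothing measured here speaks to the reason for the gain.

From the compounds shown here alone, whether an amine, a methoxy group or a fluoro group at the same position would act like bromo remains open. Also open, going by these compounds, is whether the step would hold with the different group that compound 1 carries on the shared core.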